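Trifluoromethyl in place of fluoro at the assay limit

This account rests on a few compounds, and the source may have more. Where it says the series, first, only, none or still open, it means among the compounds named here.

Measured so far in an ADME assay on HS27 cells (Homo sapiens) for antiproliferative activity, read by sulforhodamine B assay, with a stated time of 48 h (a lower number here means a stronger inhibitor, a higher number a weaker inhibitor), and reported as limits
Compound 1 `O=C(O)c1cc2cc(-c3ccc(Cl)cc3)ccc2n1O` gives > 100000 nM as a limit
Compound 2 `O=C(O)c1cc2cc(-c3ccc(F)cc3)ccc2n1O` gives > 100000 nM as a limit

Compound 2 stands at > 100000 nM in this assay as a limit of the assay and not a number. Compound 3 `O=C(O)c1cc2cc(-c3ccc(C(F)(F)F)cc3)ccc2n1O` differs from it by trifluoromethyl in place of fluoro on an aromatic carbon, para to a large group (trifluoromethyl in place of fluoro on an aromatic carbon). For the measured compounds named here, the one measured step (a step that the two limits leave unreadable from compound 1 to compound 2) offers no size to carry over. With the limit of > 100000 nM in this assay, at which 2 of the 2 values shown sit, in view, no step beyond the scatter is expected from compound 2 in this assay and a further limit is likely. The expected change is a number no higher from compound 2 to compound 3 (the limit leaves the size open) in size. For compound 3 the estimated value is 100000 nM with an expected range from 40000 nM to 250000 nM in this measurement.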

Compound 3, half-maximal inhibitory concentration: > 100000 nM
Compound 3 gave a limit, no number; the forecaster's own chance of this, stated with the estimate: 85%; the middle value lies on the limit itself.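

In this assay, for the compounds shown here, compound 3 gives > 100000 nM, a limit of the assay and not a number, and no step among compound 1, compound 2 and compound 3 can be read. The compounds shown leave open how chloro, fluoro and trifluoromethyl compare in this assay.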